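This account rests on a few compounds, and the source may have more. Where it says the series, first, only, none or still open, it means among the compounds named here.

Going by the values given here, the three compounds measured so far share one core and differ only at the end of the chain bearing the carbonyl groups. Compound 1 `O=C(O)CCC(=O)OCCCCCCSc1ccc([N+](=O)[O-])c2nonc12` carries a free acid there, and in a functional assay on 143B cells (Homo sapiens) for inhibition, read by MTT assay, with a stated time of 72 h (on this read-out higher numbers stand for weaker inhibition and lower numbers for stronger inhibition), compound 1 gives 2830 nM. Compound 2 `O=C(CCC(=O)OCCCCCCSc1ccc([N+](=O)[O-])c2nonc12)Nc1ccccc1` carries an anilide instead, and in this assay compound 2 gives 3850 nM. Compound 3 `O=C(CCC(=O)OCCCCCCSc1ccc([N+](=O)[O-])c2nonc12)Nc1ccc(F)cc1` carries a fluorinated anilide, and in this assay compound 3 gives 2500 nM. Compound 3 thus has the lowest of the three numbers, but its value lies within the scatter of both neighbours, so no order among the three can be claimed.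

Compound 4 `COc1ccc(NC(=O)CCC(=O)OCCCCCCSc2ccc([N+](=O)[O-])c3nonc23)cc1OC` arises from compound 3 by 3,4-dimethoxyphenyl in place of 4-fluorophenyl on an amide-type nitrogen. The measured steps that bear on this change are a 1.4-fold higher number from compound 1 to compound 2 (0.13 log units; within the scatter), a 1.1-fold lower number from compound 1 to compound 3 (0.05 log units; within the scatter) and a 1.5-fold lower number from compound 2 to compound 3 (0.19 log units; within the scatter): every alteration at the anilide end, from none to an aryl amide and from hydrogen to fluoro on the ring, has left the number within the scatter. On this basis a change of the ring substitution to two methoxy groups is expected to give no step beyond the scatter either, in either direction; the expected step is a 1.1-fold higher number from compound 3 to compound 4 (0.05 log units; within the scatter). Compound 4 is therefore estimated at 2800 nM, with a range from 1200 nM to 6500 nM.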

Compound 4, half-maximal inhibitory concentration: 2770 nM
For compound 4 the middle estimate is 1.0-fold (0.00 log units) above the measured one; low and high end bracket the measured number.
By their numbers in this assay, from the lowest: compounds 3, 4, 1 and 2 (each within the scatter of the next).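

In this assay, the result extends the flat picture to a ring substitution of a different kind: 3,4-dimethoxyphenyl has more heavy atoms than 4-fluorophenyl and brings hydrogen-bond acceptors that 4-fluorophenyl lacks, yet the exchange gives a 1.1-fold higher number from compound 3 to compound 4 (0.04 log units; within the scatter), and setting the same group against the plain phenyl gives a 1.4-fold lower number from compound 2 to compound 4 (0.14 log units; within the scatter). Set against the free acid, the (3,4-dimethoxyphenyl)amino group gives a 1.0-fold lower number from compound 1 to compound 4 (0.01 log units; within the scatter), so the acid and all three anilides now lie within the scatter of one another, with no compound among the four going against this. Nothing in the data shown offers an explanation for this flatness.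

The four compounds leave open whether any group at this end of the chain can move the number beyond the scatter, for instance a piperidine amide, a pyridine ring in place of the phenyl, or an amine on the ring. They also share one chain and one core, so whether a longer chain or a change to the core would shift the number remains unanswered.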